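The source may hold more compounds than are shown below. What is called first, only, known or untested is meant among the compounds shown, and "the series" means these compounds.

Measured in a functional assay on A549 cells (Homo sapiens) for cytotoxicity, read by MTT assay, with a stated time of 4 days; a higher number here means a weaker inhibitor, a lower number a stronger inhibitor:
- Compound 1 `COc1cc(C[C@H]2C(=O)OC[C@@H]2Cc2ccc(OC)c(OC)c2)ccc1NC(=O)c1ccccc1` gives > 50000 nM as a limit
- Compound 2 `COc1cc(C[C@H]2C(=O)OC[C@@H]2Cc2ccc(OC)c(OC)c2)ccc1Nc1ccccc1` gives > 50000 nM as a limit
- Compound 3 `COc1cc(C[C@H]2C(=O)OC[C@@H]2Cc2ccc(OC)c(OC)c2)ccc1NCc1ccccc1` gives > 50000 nM as a limit

In this assay compound 2 has no number and stands only at the limit > 50000 nM in this series. The whole set sits there, with the limit of > 50000 nM in this assay, at which 3 of the 3 values shown sit, as the common reading.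

Compound 4 `COc1cccc(C[C@H]2C(=O)OC[C@@H]2Cc2ccc(OC)c(OC)c2)c1` carries hydrogen in place of anilino on an aromatic carbon. The change is this: hydrogen in place of anilino on an aromatic carbon.

For the measured compounds named here, three measured steps bear on it only indirectly, as each alters the group on the nitrogen and none removes it. They are a step that the two limits leave unreadable from compound 1 to compound 2, a step that the two limits leave unreadable from compound 1 to compound 3 and a step that the two limits leave unreadable from compound 2 to compound 3. Their sizes cannot be read, so they point in no direction.

The expectation therefore rests on compound 2 and its limit of > 50000 nM in this assay. The expected change is a number no higher from compound 2 to compound 4 (the limit leaves the size open), with no direction expected from these data. Compound 4 is estimated at 50000 nM, within an expected range of 15000 nM to 100000 nM.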

Compound 4, half-maximal inhibitory concentration: > 50000 nM
Compound 4: a limit, no number; the forecaster's own chance of this, stated with the estimate: 70%; the middle value sits exactly at the limit.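

No new step can be read: compound 4 joins compound 1, compound 2 and compound 3 as a limit, not a number, in this assay: the limit of > 50000 nM in this assay, at which 4 of the 4 values shown sit.

The compounds shown leave open whether any of these changes on the aromatic ring alters cytotoxicity at all.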